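Moving the Chlorine Around the Amide-Side Phenyl Ring

A few compounds are considered here, and "the series" means these few. Any claim that something is new, unique, unknown or untested is made for them only; others in the source may bear on it.

Compounds measured in a functional assay on MDA-MB-231 cells (Homo sapiens) for inhibition, read by MTT assay, with a stated time of 72 h; on this read-out lower numbers stand for stronger inhibition and higher numbers for weaker inhibition:
- compound 1, `O=C(CSc1nc(Nc2ccccc2)c2ccccc2n1)Nc1ccccc1Cl`, gives 24400 nM
- compound 2, `O=C(CSc1nc(Nc2ccccc2)c2ccccc2n1)Nc1cccc(Cl)c1`, gives 16500 nM
- compound 3, `O=C(CSc1nc(Nc2ccccc2)c2ccccc2n1)Nc1ccc(F)cc1`, gives 34100 nM

All three share one core and differ only in the phenyl ring on the amide nitrogen. Compound 2 has the lowest number of the three, but its step to compound 1 is small: a 1.5-fold lower number from compound 1 to compound 2 (0.17 log units; within the scatter). Only its step to compound 3 is beyond the scatter: a 2.1-fold higher number from compound 2 to compound 3 (0.32 log units; beyond the scatter).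

Compound 4, `O=C(CSc1nc(Nc2ccccc2)c2ccccc2n1)Nc1ccc(Cl)cc1`, is the next variation. Its change from compound 2 is 4-chlorophenyl in place of 3-chlorophenyl on an amide-type nitrogen. Among the compounds with values here, the steps that bear on it are the two chlorine moves already seen: a 1.5-fold lower number from compound 1 to compound 2 (0.17 log units; within the scatter) and a 1.4-fold higher number from compound 1 to compound 3 (0.15 log units; within the scatter), both within the scatter, alongside the modest step of a 2.1-fold higher number from compound 2 to compound 3 (0.32 log units; beyond the scatter). Shifting a single chlorine around this ring has so far changed little, and the one exchange that went beyond the scatter went toward a higher number. Compound 4 is therefore expected to sit close to compound 2, with a step of a 1.3-fold higher number from compound 2 to compound 4 (0.12 log units; within the scatter) in this assay. The estimate for compound 4 is 22000 nM, within a range from 11000 nM to 45000 nM.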

Compound 4, half-maximal inhibitory concentration: 17200 nM
The estimate for compound 4 lay 1.3-fold (0.11 log units) above the measured number; measured number inside the range.
By their numbers in this assay, from the lowest: compounds 2, 4, 1 and 3 (each within the scatter of the next, the first and the last beyond it).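

In this assay, moving the chlorine from 3-chlorophenyl to 4-chlorophenyl makes no readable difference: a 1.0-fold higher number from compound 2 to compound 4 (0.02 log units; within the scatter). The same holds for 4-chlorophenyl in place of 2-chlorophenyl, at a 1.4-fold lower number from compound 1 to compound 4 (0.15 log units; within the scatter), so the three chlorine placements now read alike, and chloro in place of fluoro gives a 2.0-fold lower number from compound 3 to compound 4 (0.30 log units; within the scatter), which stays within the scatter although the step from compound 2 to compound 3 lay beyond it. No measurement here offers an explanation for these numbers.

The compounds shown carry only a single chloro or fluoro on this ring, so the effect of a methoxy group, a nitrile or a carboxylic acid there remains open. Also open, as far as these compounds go, is whether an amine or a longer chain on the amide-type nitrogen, in place of the substituted phenyl, would shift the number further.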